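This account rests on a few compounds, and the source may have more. Where it says the series, first, only, none or still open, it means among the compounds named here.

Measured so far in an in vitro functional assay on HEK293-A cells for positive allosteric modulation of metabotropic glutamate receptor 5 (Homo sapiens), read by FLIPR and calcium flux; a higher number here means that more compound is needed for the effect, a lower number that less compound is needed:
compound 1, `O=C1CC(c2nc(-c3cccc(F)c3)no2)CN1c1ccc(Cl)cc1`: 630 nM.
compound 2, `O=c1oc2ccccc2n1Cc1nc(-c2cccc(Cl)c2)no1`: > 10000 nM.
compound 3, `O=C1CC(c2nc(-c3cccc(Cl)c3)no2)CN1c1cccc(Cl)c1`: > 10000 nM.

The reported value of compound 2 is a limit of the assay, not a number. The reported value of compound 3 is likewise a limit, not a number. Compound 3 therefore stands at the limit of > 10000 nM in this assay, at which 2 of the 3 values shown sit, and compound 1 is the only one of the three to give a number in this assay.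

Among the compounds with values here, no pair of measured compounds differs in a single place, so no step size is known from the data. Compound 4, `O=C1CC(c2nc(-c3cccc(Cl)c3)no2)CN1c1ccc(Cl)c(Cl)c1`, differs from compound 3 by chloro in place of hydrogen on an aromatic carbon. With nothing to lean on, the expected step of an at least 1.6-fold lower number from compound 3 to compound 4 (0.22 log units; that floor lies within the scatter) is toward less compound needed, but only modestly and with wide uncertainty. Compound 4 is estimated at 6000 nM, within a range of 1500 nM to 20000 nM.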

Compound 4, half-maximal effective concentration: 460 nM
Estimate against measurement, compound 4: 13-fold (1.12 log units) above, outside the stated range (below it).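

In this assay, within the data shown here, the change from 3-chlorophenyl to 3,4-dichlorophenyl gives an at least 21-fold lower number from compound 3 to compound 4 (1.33 log units; beyond the scatter), the first single-place step, and it brings the compound from a limit to a measured number. Compound 3 gives > 10000 nM, which is a limit of the assay and not a number, so the printed step is only a floor. This aromatic carbon, para to a large group and ortho to a chloro group, is therefore a position where one added chlorine counts for much.

As far as these compounds go, whether fluoro, methyl or a nitrile at this position would give a comparable step remains open. So does whether the step depends on the chloro group already on that ring.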